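Removing trifluoromethyl from compound 2: expected efficacy

The compounds below may be only part of what the source reports. "The series", "measured", "known", "first", "only" and "open" are said of these compounds alone.

Measured so far:
- compound 1 `CN(C)CCC(NC(=O)CCc1ccccc1)c1ccc2ccccc2c1`: in a functional assay on NIH3T3 cells for agonist activity at Urotensin-2 receptor (Homo sapiens), with a stated time of 5 days (on this read-out higher numbers stand for larger maximal responses and lower numbers for smaller maximal responses), compound 1 gives 107%
- compound 2 `CN(C)CCC(NC(=O)/C=C/c1ccc(C(F)(F)F)cc1)c1ccc2ccccc2c1`: in this assay compound 2 gives 117%

Both numbers lie near the reference response. Compound 2 carries the higher of the two, but its gap to compound 1 falls within the scatter of repeated measurements, so the two compounds read alike on this assay.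

Compound 3 `CN(C)CCC(NC(=O)/C=C/c1ccccc1)c1ccc2ccccc2c1` is to be measured in this assay and differs from compound 2 by hydrogen in place of trifluoromethyl on an aromatic carbon. Among the measured compounds shown here, no step between measured compounds is available to size this change from earlier data.

Because compound 1 gives 107% and compound 2 gives 117%, both near full response, the step of a number 7 percentage points lower from compound 2 to compound 3 (within the scatter) is expected to be none beyond the scatter in either direction. For compound 3 the estimate in this assay is 110%, with a range from 90% to 130%.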

Compound 3, largest response reached (reported as efficacy), in percent of the reference or control that the assay uses: 116%
For compound 3 the middle estimate is 6 percentage points below the measured one, within the range that was stated.
By their numbers in this assay, from the lowest: compounds 1, 3 and 2 (each within the scatter of the next).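

In this assay hydrogen in place of trifluoromethyl on the aromatic carbon gives a number 1 percentage points lower from compound 2 to compound 3 (within the scatter) and so, for this pair, the maximal response does not depend on trifluoromethyl at this place. The linker also makes no difference beyond the scatter: 2-phenylethenyl in place of phenethyl on the carbonyl carbon gives a number 9 percentage points higher from compound 1 to compound 3 (within the scatter) and so compound 1 and compound 3 read alike. No measurement at hand accounts for either step.

Still open, going by these compounds, is whether an amine or a carboxylic acid on this aromatic carbon would read alike too, and whether a longer chain between the carbonyl and the phenyl ring would keep the response. These maximal responses also leave open how the compounds compare in potency at this receptor.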